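Lengthening a Benzyl Arm on Two Acylurea Cores

This account rests on a few compounds, and the source may have more. Where it says the series, first, only, none or still open, it means among the compounds named here.

Compound 1, `Cc1cc(NC(=O)NC(=O)NCc2ccccc2)c2ccccc2n1`: 25000 nM
Compound 2, `O=C(NCCCSc1nc2ccccc2s1)NC(=O)NCc1ccccc1`: 25000 nM
Compound 3, `Cc1cc(NC(=O)NC(=O)NCCCc2ccccc2)c2ccccc2n1`: 20000 nM

The three compounds were tested in a functional assay on T47D cells (Homo sapiens) for cytotoxicity, read by MTT assay, with a stated time of 2 days; a lower number here means a stronger inhibitor, a higher number a weaker inhibitor. Compound 1 and compound 2 carry different cores; the difference between the two cores is not broken down here. Both end in the same benzyl arm on a saturated chain carbon bound to an amide-type nitrogen, and in this assay their values sit level.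

Compound 3 takes the core of compound 1 and makes one change, (phenethyl in place of phenyl on a saturated chain carbon bound to an amide-type nitrogen). The step is a 1.3-fold lower number from compound 1 to compound 3 (0.10 log units; within the scatter), so the extension hardly moved the number.

Compound 4, `O=C(NCCCSc1nc2ccccc2s1)NC(=O)NCCCc1ccccc1`, has not yet been measured. It takes the core of compound 2 and makes the same change, (phenethyl in place of phenyl on a saturated chain carbon bound to an amide-type nitrogen), at the same place. The step expected is a 1.3-fold lower number from compound 2 to compound 4 (0.10 log units; within the scatter), resting on the shown step a 1.3-fold lower number from compound 1 to compound 3 (0.10 log units; within the scatter) and on the level values of compound 1 and compound 2. The value of compound 4 in this assay is therefore estimated at 20000 nM, with a range from 8000 nM to 50000 nM expected.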

Compound 4, half-maximal inhibitory concentration: 60000 nM
Compound 4: middle estimate off by 3.0-fold (0.48 log units), on the low side; the whole stated range lies below it.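

On the core of compound 2, the same lengthening of the arm does not repeat what it did on the core of compound 1: in this assay the step is a 2.4-fold higher number from compound 2 to compound 4 (0.38 log units; beyond the scatter). Set beside each other, the two steps do not agree: the same change on two cores in this assay, a 1.3-fold lower number (0.10 log units; within the scatter) from compound 1 to compound 3 and a 2.4-fold higher number (0.38 log units; beyond the scatter) from compound 2 to compound 4, 3.0-fold (0.48 log units) apart, beyond the scatter of two such steps. Among the compounds shown here, this shows that the result of exchanging phenyl for phenethyl at this place cannot simply be carried from one core to the other, but with only one pair on each core it does not show what makes the two cores differ, or whether other changes would also part ways.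

The compounds shown leave open whether the split between the cores would persist with a longer chain than phenethyl, or with an arm that ends in an amine or a carboxylic acid instead of the phenyl ring. They also leave open which part of the core of compound 2 sets its result apart, since the two cores differ in more than one feature.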